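From 3,5-Dimethylphenyl to 4-Methylphenyl on Compound 2

This account rests on a few compounds, and the source may have more. Where it says the series, first, only, none or still open, it means among the compounds named here.

Measured so far in a functional assay on CHP-134 cells (Homo sapiens) for antiproliferative activity, with a stated time of 72 h; on this read-out higher numbers stand for weaker inhibition and lower numbers for stronger inhibition:
Compound 1 `Cc1ccc(NC(=O)CCN(Cc2ccc(C(=O)NO)cc2)C(=O)c2cc(C)cc(C)c2)cc1`: 380 nM
Compound 2 `Cc1cc(C)cc(C(=O)N(CCC(=O)NCc2ccccc2)Cc2ccc(C(=O)NO)cc2)c1`: 2030 nM

Of these two, compound 2 gives the higher number, 2030 nM, and so the weaker inhibition. The gap is a 5.3-fold higher number from compound 1 to compound 2 (0.73 log units; beyond the scatter), which lies beyond the usual scatter and goes with benzyl in place of 4-methylphenyl on an amide-type nitrogen.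

Compound 3 `Cc1ccc(C(=O)N(CCC(=O)NCc2ccccc2)Cc2ccc(C(=O)NO)cc2)cc1` keeps that benzyl and differs from compound 2 elsewhere: 4-methylphenyl in place of 3,5-dimethylphenyl on a carbonyl carbon. In words, this is 4-methylphenyl in place of 3,5-dimethylphenyl on a carbonyl carbon.

Going by the values given here, the one measured step sits at a different place in the molecule, so it does not test this swap. Among the compounds with values here, it shows only that changing a single group can shift this assay modestly, in this case a 5.3-fold higher number from compound 1 to compound 2 (0.73 log units; beyond the scatter). With no measured change at this carbonyl carbon, the starting point remains compound 2 at 2030 nM, and no step beyond the scatter is expected, although the range must stay wide in both directions. The expected step is a 1.1-fold lower number from compound 2 to compound 3 (0.05 log units; within the scatter). Compound 3 is estimated at 1800 nM, with an expected range of 700 nM to 4500 nM.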

Compound 3, half-maximal inhibitory concentration: 1100 nM
Compound 3: the middle estimate sits 1.6-fold (0.21 log units) above what was measured; low and high end bracket the measured number.
By their numbers in this assay, from the lowest: compound 1; then compounds 3 and 2 (each within the scatter of the next).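

In this assay, going by these compounds alone, the first look at this carbonyl carbon gives a 1.8-fold lower number from compound 2 to compound 3 (0.27 log units; within the scatter) and so shows that, with benzyl held fixed on the amide-type nitrogen, 4-methylphenyl and 3,5-dimethylphenyl cannot be told apart in this assay. The swap alters both the number of methyl groups and where they sit on the ring, and this single step cannot separate those two changes; it shows only that together they leave the result within the usual scatter. No measurement here offers an explanation for how closely these two groups read.

The compounds shown leave open whether the same swap would also stay within the scatter on the background of compound 1, where 4-methylphenyl rather than benzyl sits on the amide-type nitrogen. They also leave open how this carbonyl carbon would respond to a group of a different kind from these methyl-bearing phenyl rings, such as a phenyl ring carrying an amine or a carboxylic acid, or a longer carbon chain.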